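Moving a Methyl Group Along a Phenyl Ring

A few compounds are considered here, and "the series" means these few. Any claim that something is new, unique, unknown or untested is made for them only; others in the source may bear on it.

Measured compounds and their values:
Compound 1, `Cc1ccccc1-n1c(Nc2nc(-c3ccccc3)cs2)n[nH]c1=S`: 100 mg/kg
Compound 2, `COc1ccccc1-n1c(Nc2nc(-c3ccccc3)cs2)n[nH]c1=S`: 100 mg/kg
Compound 3, `Cc1ccc(-n2c(Nc3nc(-c4ccc([N+](=O)[O-])cc4)cs3)n[nH]c2=S)cc1`: 100 mg/kg

All three compounds were tested in a functional assay on the whole organism (strain Swiss albino) for inhibition, with Mus musculus as the target, with a stated time of 0.5 h; on this read-out lower numbers stand for an effect already at smaller amounts and higher numbers for an effect only at larger amounts of compound. In this assay compound 3 gives 100 mg/kg, which stands level with compound 1 and compound 2 at the digits shown; the closest neighbour is compound 1, and even the furthest, compound 2, sits within the scatter.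

Compound 4, `Cc1ccccc1-n1c(Nc2nc(-c3ccc([N+](=O)[O-])cc3)cs2)n[nH]c1=S`, has not yet been measured. It differs from compound 3 in one place: 2-methylphenyl in place of 4-methylphenyl on an aromatic nitrogen. The same atoms are present, only joined differently.

Among the compounds with values here, only one measured step is available, and it concerns a different position: no change at the digits printed from compound 1 to compound 2 (within the scatter), a change on an aromatic carbon rather than on the aromatic nitrogen. It bears on the present question only loosely, but it shows that a small swap on a phenyl ring left the read-out unchanged. Compound 1 also carries 2-methylphenyl on the aromatic nitrogen and gives the same value as compound 3. On this basis no step beyond the scatter is expected, no change at the digits printed from compound 3 to compound 4 (within the scatter). Compound 4 is therefore estimated at 100 mg/kg, with a range from 50 mg/kg to 200 mg/kg.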

Compound 4, minimum effective dose: 100 mg/kg
For compound 4 middle estimate and measured number coincide at the digits printed, within the range that was stated.
By their numbers in this assay, from the lowest: compounds 1, 2, 3 and 4 (each within the scatter of the next).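

In this assay, within the data shown here, moving the methyl group around the phenyl ring on the aromatic nitrogen gives no change at the digits printed from compound 3 to compound 4 (within the scatter), so for this pair the read-out does not register where the methyl group sits, something the earlier compounds could not show because none of them formed such a pair. The second new step adds a change at a different site: nitro in place of hydrogen on an aromatic carbon gives no change at the digits printed from compound 1 to compound 4 (within the scatter), so with 2-methylphenyl on the nitrogen, this added group also leaves the value where it was. Among these compounds, no measurement here accounts for either result, and the data show only that the values coincide, not what lies behind them.

With every value level, these compounds give no sign of which parts of the structure the read-out depends on, since no change shown has yet moved it beyond the scatter. As far as these compounds go, it remains open whether a different group on the same phenyl ring, such as an amine, a carboxylic acid or a longer chain like butyl, would move the minimum effective dose in either direction.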